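Shared-core series: acetoxy in place of the aroyl group

This account rests on a few compounds, and the source may have more. Where it says the series, first, only, none or still open, it means among the compounds named here.

Measured so far in a functional assay (aorta) with Rattus norvegicus as the target; a higher number here means a more potent compound, by a factor of ten per unit of this negative logarithm, a lower number a less potent compound:
compound 1 `CCC(=O)c1ccc2c(c1)C(n1ccccc1=O)=CC(C)(C)O2`: 6.63
compound 2 `CC1(C)C=C(n2ccccc2=O)c2cc(C(=O)c3ccccc3)ccc2O1`: 6.61
compound 3 `Cc1ccccc1C(=O)c1ccc2c(c1)C(n1ccccc1=O)=CC(C)(C)O2`: 6.83

Of the three numbers, compound 2 has the smallest, yet the step of a number 0.02 log units lower from compound 1 to compound 2 (within the scatter) and the step of a number 0.22 log units higher from compound 2 to compound 3 (within the scatter) both lie within the scatter, as does a number 0.20 log units higher from compound 1 to compound 3 (within the scatter); the three substituents on that aromatic carbon are not told apart.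

Compound 4 `CC(=O)Oc1ccc2c(c1)C(n1ccccc1=O)=CC(C)(C)O2` differs from compound 2 by acetoxy in place of benzoyl on an aromatic carbon. Every measured step at this carbon is within the scatter, so no step beyond the scatter is expected here either. Acetoxy, however, brings no carbon ring, unlike anything measured, so the range is kept wide. Compound 4 is expected to give 6.5, between 5.8 and 7.1. The expected step is a number 0.11 log units lower from compound 2 to compound 4 (within the scatter).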

Compound 4, logarithm of the reciprocal of the active concentration, log(1/C): 5.6
Beside the measured number, compound 4's estimate is 0.90 log units above it, outside the stated range (below it).
By their numbers in this assay, from the lowest: compound 4; then compounds 2, 1 and 3 (each within the scatter of the next).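

Within the data shown here, at this aromatic carbon the substituent now matters in this assay: acetoxy gives the first steps here beyond the scatter (a number 1.01 log units lower from compound 2 to compound 4 (beyond the scatter)) and (a number 1.03 log units lower from compound 1 to compound 4 (beyond the scatter)) and (a number 1.23 log units lower from compound 3 to compound 4 (beyond the scatter)). Propanoyl, which has no ring, stays within the scatter of benzoyl and (2-methylphenyl)carbonyl, so the absence of a carbon ring alone does not go with the drop. No available evidence bears on this drop.

The compounds shown leave open whether the drop goes with the oxygen joining acetoxy to the aromatic carbon or with the acetoxy group as a whole. A benzoyloxy ester or a methoxy group at this carbon would bear on that.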